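One Group Exchanged on an Amide-Type Nitrogen

A few compounds are considered here, and "the series" means these few. Any claim that something is new, unique, unknown or untested is made for them only; others in the source may bear on it.

Compound 1, `C/C(=N/NC(=O)Nc1nnc(COc2ccc3ccccc3c2)o1)c1ccc(N)cc1`, was tested in a functional assay on the whole organism (strain Swiss albino) with Mus musculus as the target, in the maximal electroshock model, with a stated time of 4 h; on this read-out lower numbers stand for an effect already at smaller amounts and higher numbers for an effect only at larger amounts of compound. In this assay compound 1 gives 300 mg/kg. Compound 2, `O=C(N/N=C(/c1ccccc1)c1ccc([N+](=O)[O-])cc1)Nc1nnc(COc2ccc3ccccc3c2)o1`, shares the same core, and in this assay compound 2 gives 300 mg/kg, so compound 1 stands level with compound 2 at the digits shown, a gap that lies within the usual scatter of such measurements. Compound 3, `Cc1ccc(/C=N\NC(=O)Nc2nnc(COc3ccc4ccccc4c3)o2)cc1`, has not yet been measured. It differs from compound 1 in a single place: a group of 9 heavy atoms (8 carbon, 1 nitrogen; one six-membered aromatic ring of carbon only) in place of a group of 10 heavy atoms (8 carbon, 2 nitrogen; one six-membered aromatic ring of carbon only), on an amide-type nitrogen. Within the data shown here, because compound 1 gives 300 mg/kg and compound 2 gives 300 mg/kg, the two known values sit at one level, and no measured step between neighbouring compounds exists that could show how large a change of this kind is. The expected step is therefore no change at the digits printed from compound 1 to compound 3 (within the scatter), nothing beyond the scatter. For compound 3 the expected result in this assay is 300 mg/kg, with a range from 100 mg/kg to 600 mg/kg.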

Compound 3, minimum effective dose: 300 mg/kg
For compound 3 middle estimate and measured number coincide at the digits printed; the measured number falls inside the stated range.
By their numbers in this assay, from the lowest: compounds 1, 2 and 3 (each within the scatter of the next).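

Among these compounds, this result gives the first reading of a single exchange on this amide-type nitrogen: in this assay the step is no change at the digits printed from compound 1 to compound 3 (within the scatter). The group that leaves has 1 hydrogen-bond donor and 2 hydrogen-bond acceptors, the group that enters has 0 hydrogen-bond donors and 1 hydrogen-bond acceptor, and this difference in the counts comes with no shift in the dose beyond the scatter. No measurement here bears on why the two compounds read alike.

A single pair cannot show whether other groups at this nitrogen would also leave the dose in place, such as one carrying a carboxylic acid or a plain butyl chain with no ring. It also leaves open whether the same exchange would read alike on a different core.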